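Compound 3 to compound 4: replacing the pyridin-2-yl group

The compounds below may be only part of what the source reports. "The series", "measured", "known", "first", "only" and "open" are said of these compounds alone.

In a functional assay on SW-620 cells (Homo sapiens) for antiproliferative activity, read by MTT assay, with a stated time of 24 h (on this read-out lower numbers stand for stronger inhibition and higher numbers for weaker inhibition), compound 3 (`COc1ccc(C(=O)/C=C/c2ccccn2)c2c1C=CC(C)(C)O2`) gives 5000 nM. That is the higher of the two true numbers in the series, since compound 2 (`CCN(CC)c1ccc(/C=C/C(=O)c2ccc(OC)c3c2OC(C)(C)C=C3)cc1`) gives 670 nM. Compound 1 (`COc1ccc(C(=O)/C=C/c2cccc(F)c2)c2c1C=CC(C)(C)O2`) gives > 10000 nM, which is a limit of the assay and not a number.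

The next compound is compound 4 (`COc1ccc(C(=O)/C=C/c2ccc(Cl)cc2)c2c1C=CC(C)(C)O2`), with 4-chlorophenyl in place of pyridin-2-yl on a double-bonded chain carbon bound to a double-bonded chain carbon.

For the measured compounds named here, the one measured step at this place is an at least 2.0-fold lower number from compound 1 to compound 3 (0.30 log units; that floor lies within the scatter). It is only a floor, because of the limit of > 10000 nM in this assay, at which 1 of the 3 values shown sits. That step does not give a firm size for a swap of these rings. Compound 4 returns to a six-membered aromatic ring of carbon only, as in compound 1. Compound 2 also has such a ring and gives 670 nM, so compound 1 and compound 2 show that this ring type does not set one level.

No step beyond the scatter is therefore expected in this assay, and the estimated change is a 1.2-fold higher number from compound 3 to compound 4 (0.08 log units; within the scatter). For compound 4 the estimate is 6000 nM, with an expected range from 1500 nM to 15000 nM.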

Compound 4, half-maximal inhibitory concentration: > 10000 nM
Compound 4: only a limit was reported; the forecaster's own chance of this, stated with the estimate: 35%; at least 1.6-fold (0.22 log units) between middle value and limit.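

In this assay, chloro in place of diethylamino on an aromatic carbon gives an at least 14-fold higher number from compound 2 to compound 4 (1.17 log units; beyond the scatter), which makes this the first firm size for a change at this end of the series and shows that the group carried on the carbon-only aromatic ring can decide the level. By contrast, 4-chlorophenyl in place of pyridin-2-yl gives an at least 2.0-fold higher number from compound 3 to compound 4 (0.30 log units; that floor lies within the scatter), a floor that stays within the scatter, so this ring swap still has no firm size. Among the three carbon-only aromatic rings shown, only the diethylamino compound gives a true number, and the step from compound 1 to compound 4 cannot be read, as both values are limits: the limit of > 10000 nM in this assay, at which 2 of the 4 values shown sit.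

The compounds shown leave open whether the gain belongs to diethylamino itself or to amines more widely, for instance dimethylamino or piperidin-1-yl on the same aromatic carbon, measured against compound 2 at 670 nM. They also leave open whether a methoxy group at that place would give a true number, and how compound 1 and compound 4 rank against each other.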